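A few compounds are considered here, and "the series" means these few. Any claim that something is new, unique, unknown or untested is made for them only; others in the source may bear on it.

Compound 1 `Brc1ccccc1Cn1ccc2nc(-c3ccccc3)nc-2c1` was examined in an ADME assay on MDBK cells (Bos taurus) for cytotoxicity; a lower number here means that less compound is tolerated, a higher number that more compound is tolerated. In this assay compound 1 gives > 100000 nM, which is a limit of the assay and not a number. Compound 2 `FC(F)(F)c1ccccc1Cn1ccc2nc(-c3ccccc3)nc-2c1` likewise gives > 100000 nM, again a limit of the assay rather than a number. The step that the two limits leave unreadable from compound 1 to compound 2 is thus not readable in size. Within the data shown here, compound 3 `c1ccc(-c2nc3ccn(Cc4ccc5ccccc5c4)cc-3n2)cc1` gives 67000 nM, the only numerical value among the three. The evidence comes down to the limit of > 100000 nM in this assay, at which 2 of the 3 values shown sit.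

The unmeasured compound 4 `c1ccc(-c2nc3ccn(Cc4cccnc4)cc-3n2)cc1` differs from compound 1 as follows: pyridin-3-yl in place of 2-bromophenyl on a saturated chain carbon bound to an aromatic nitrogen. Among the measured compounds shown here, no measured step bears directly on this change: the single measured step between compound 1 and compound 2 is unreadable, and compound 3 stands on a different change. With compound 1 itself sitting at a limit, the step of a number no higher from compound 1 to compound 4 (the limit leaves the size open) is expected to be none beyond the scatter. For compound 4 the expected value in this assay is 100000 nM, with a range from 40000 nM to 300000 nM, and it is thought likely that only a limit will again be reported.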

Compound 4, half-maximal cytotoxic concentration: > 100000 nM
Compound 4: only a limit was reported; the forecaster's own chance of this, stated with the estimate: 65%; the middle value lies on the limit itself.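

In this assay compound 4 gives > 100000 nM, which is a limit of the assay and not a number. Among these compounds, compound 1 also stands at a limit, so no step between compound 1 and compound 4 can be read. The compounds shown leave open how far tolerated concentrations at this limit actually lie apart.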